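The compounds below may be only part of what the source reports. "The series", "measured", "known", "first", "only" and "open" are said of these compounds alone.

The values below come from an ADME assay on HUVEC cells (Homo sapiens) for antiproliferative activity, read by MTT assay, with a stated time of 48 h; on this read-out lower numbers stand for stronger inhibition and higher numbers for weaker inhibition.

Compound 1 `N#CC1=C(N)Oc2c(c3nc4ccccc4nc3c3ccccc23)C12C(=O)N(Cc1cnnn1-c1cccc(S(N)(=O)=O)c1)c1ccccc12`: 38600 nM
Compound 2 `Cc1cc(C)cc(-n2nncc2CN2C(=O)C3(C(C#N)=C(N)Oc4c3c3nc5ccccc5nc3c3ccccc43)c3ccccc32)c1`: > 50000 nM
Compound 3 `COc1ccccc1-n1nncc1CN1C(=O)C2(C(C#N)=C(N)Oc3c(N)cc4nc5ccccc5nc4c32)c2ccccc21`: > 50000 nM

Compound 1 is the only one of the three with a numerical result in this assay. For compound 2 the value is a limit of the assay and not a number. Among the measured compounds shown here, the only directly measured change on the aromatic nitrogen, an at least 1.2-fold higher number from compound 1 to compound 2 (0.11 log units; that floor lies within the scatter), is therefore known only as a floor, and that floor lies within the usual scatter; its size is bounded below by the limit of > 50000 nM in this assay, at which 2 of the 3 values shown sit. Compound 3 likewise gives only a limit of the assay in this assay, so its standing among the three is known only as a bound, with two of the three results sitting at that bound.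

Compound 4 `Cc1cc(C)c(-n2nncc2CN2C(=O)C3(C(C#N)=C(N)Oc4c(N)cc5nc6ccccc6nc5c43)c3ccccc32)c(C)c1` differs from compound 3 in one place: 2,4,6-trimethylphenyl in place of 2-methoxyphenyl on an aromatic nitrogen. For the measured compounds named here, the one measured step that bears on it, the aryl swap on the same nitrogen from compound 1 to compound 2, reached the limit, so no step beyond the scatter is expected in this assay in either direction. Compound 4 is expected to remain at the limit, estimated at 60000 nM with a range from 20000 nM to 150000 nM, meaning an expected step that the limit leaves unreadable from compound 3 to compound 4.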

Compound 4, half-maximal inhibitory concentration: > 50000 nM
Compound 4 ended at the assay's limit; the forecaster's own chance of this, stated with the estimate: 85%; the middle value does not contradict the limit.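

No step can be read between compound 3 and compound 4 in this assay, since both results are limits of the assay and not numbers: the limit of > 50000 nM in this assay, at which 3 of the 4 values shown sit.

The compounds shown leave open where compound 2, compound 3 and compound 4 truly lie beyond that limit, and so whether swapping the aryl group on the aromatic nitrogen changes the read-out at all.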